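Imidazolyl to dimethylamino on the propargylic carbon

The source may report more compounds than this note shows. Statements on the series, on what has been measured and on what is new or still open speak of the compounds shown alone.

Compound 1 `CC1CCC(=O)N1CC#CCn1ccnc1` is characterised in a functional assay on the whole organism for agonist activity, with Mus musculus as the target; a higher number here means that more compound is needed for the effect, a lower number that less compound is needed. For compound 1 only a limit is recorded, > 100 mg/kg, and no number. Compound 2 `CC1CCC(=O)N1CC#CCN(C)C` gives 3 mg/kg in this assay. The step of an at least 33-fold lower number from compound 1 to compound 2 (1.52 log units; beyond the scatter) marks the change (dimethylamino in place of 1H-imidazol-1-yl on a saturated chain carbon bound to a triple-bonded carbon), and the size of this step is bounded by the limit of > 100 mg/kg in this assay, at which 1 of the 3 values shown sits, so it may well be larger than stated.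

Compound 3 `COC(=O)N(C)C(C)C#CCn1ccnc1` carries a different core; the difference between the core of compound 3 and the core of compound 1 is not broken down here. In this assay compound 3 gives 8 mg/kg, the highest of the two numbers recorded.

Compound 4 `COC(=O)N(C)C(C)C#CCN(C)C` has not yet been measured. It differs from compound 3 by dimethylamino in place of 1H-imidazol-1-yl on a saturated chain carbon bound to a triple-bonded carbon, the same change already seen from compound 1 to compound 2, at the same place. Resting on that measured step, a drop in this assay of a 5.3-fold lower number from compound 3 to compound 4 (0.73 log units; beyond the scatter) is expected from compound 3 to compound 4, though the starting point is already lower. For compound 4 the estimate is 1.5 mg/kg, most plausibly between 0.4 mg/kg and 6 mg/kg.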

Compound 4, dose for half-maximal effect: 17.3 mg/kg
Estimate against measurement, compound 4: 12-fold (1.06 log units) below; measured number outside the range, above it.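

In this assay, dimethylamino in place of 1H-imidazol-1-yl on a saturated chain carbon bound to a triple-bonded carbon gives a 2.2-fold higher number from compound 3 to compound 4 (0.33 log units; beyond the scatter), so the direction seen on the core of compound 1 does not carry over to the core of compound 3. Set side by side, the two steps do not agree: the same change on two cores in this assay, an at least 33-fold lower number (1.52 log units; beyond the scatter) from compound 1 to compound 2 and a 2.2-fold higher number (0.33 log units; beyond the scatter) from compound 3 to compound 4, at least 72-fold (1.85 log units) apart, beyond the scatter of two such steps

Compound 1 stands at a limit and not at a number, so the gap may be wider still, and two pairs give neither a reason for the reversal nor a rule for further cores: the limit of > 100 mg/kg in this assay, at which 1 of the 4 values shown sits.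

Open, as far as these compounds go, is which part of the difference between the core of compound 1 and the core of compound 3 decides the direction of the step. Also open, from the compounds shown here alone, is whether diethylamino or a primary amine on the same saturated chain carbon would follow dimethylamino on either core, and whether a longer chain would alter the picture.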